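This account rests on a few compounds, and the source may have more. Where it says the series, first, only, none or still open, it means among the compounds named here.

Compounds measured in a functional assay on Huh-7 cells (Homo sapiens) for cytotoxicity, read by CCK-8 assay, with a stated time of 72 h; a lower number here means a stronger inhibitor, a higher number a weaker inhibitor:
- compound 1, `C=CCn1c(=O)/c(=C\c2cccc(Cl)c2)[nH]c(=O)/c1=C\c1ccccc1OC`: 8900 nM
- compound 2, `C=CCn1c(=O)/c(=C\c2ccccc2Cl)[nH]c(=O)/c1=C\c1ccccc1OC`: 6400 nM
- compound 3, `C=CCn1c(=O)/c(=C\c2ccc(Cl)c(Cl)c2)[nH]c(=O)/c1=C\c1ccccc1OC`: "not active" (no number reported) (no number reported)

Compound 3 thus stands apart from the two numbered compounds in this assay; it carries no single value, only the report that it showed no measurable effect. Compound 4, `C=CCn1c(=O)/c(=C\c2ccccc2OC)[nH]c(=O)/c1=C\c1ccccc1OC`, is not yet measured.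

The change from compound 3 to compound 4 is 2-methoxyphenyl in place of 3,4-dichlorophenyl on a double-bonded chain carbon bound to an aromatic carbon. Among the compounds with values here, no measured pair covers this swap directly. Within the data shown here, the only step at hand, a 1.4-fold lower number from compound 1 to compound 2 (0.14 log units; within the scatter), moves a chlorine around the ring and is within the scatter, so it says little about exchanging two chlorines for a methoxy group. What the numbers do show is that compounds 1 and 2, each carrying a single chlorine on that ring, give numbers in the assay, whereas compound 3 with two chlorines gives none.

Compound 4 is therefore expected to return to the range of compounds 1 and 2 rather than to stay unmeasurable, with wide uncertainty; the estimate for compound 4 in this assay is 10000 nM, between 3000 nM and 40000 nM.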

Compound 4, half-maximal inhibitory concentration: 21200 nM
For compound 4 the middle estimate is 2.1-fold (0.33 log units) below the measured one; the range from low to high includes it.
By their numbers in this assay, from the lowest: compounds 2 and 1 (each within the scatter of the next); then compound 4.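

In this assay, the place on a double-bonded chain carbon bound to an aromatic carbon can lose chlorine altogether and still give a number: compound 4, with 2-methoxyphenyl, gives 21200 nM against compound 3, with 3,4-dichlorophenyl, at "not active" (no number reported) in the same assay. Unlike the chlorine shift, this change has a size that can be read: methoxy in place of chloro gives a 3.3-fold higher number from compound 2 to compound 4 (0.52 log units; beyond the scatter) and 2-methoxyphenyl in place of 3-chlorophenyl gives a 2.4-fold higher number from compound 1 to compound 4 (0.38 log units; beyond the scatter) as well, so both modest steps go the same way. No measurement at hand bears on why the number moves.

Open, from the compounds shown here alone, is whether 3-methoxyphenyl would read like the 2-methoxyphenyl of compound 4. Also open, going by these compounds, is whether an amine or a carboxylic acid on this ring gives any number in this assay at all.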